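The source may report more compounds than this note shows. Statements on the series, on what has been measured and on what is new or still open speak of the compounds shown alone.

Compound 1 `COc1cc(N(CC2CC2)c2ccc(Cl)c(Cl)c2)cnc1C(=O)[C@H]1C[C@@H]1C(=O)O` gives 4.94 nM in an assay for inhibition of leukotriene C4 synthase (Homo sapiens), read by LC-MS, with stated times of 15 min and 30 min; a lower number here means a stronger inhibitor, a higher number a weaker inhibitor.
Compound 2 `COc1cc(N(CC2CC2)c2cccc(C(F)(F)F)c2)cnc1C(=O)[C@H]1C[C@@H]1C(=O)O` gives 6.42 nM in this assay.
Compound 3 `COc1cc(N(Cc2ccc(F)cc2)c2cccc(C(F)(F)F)c2)cnc1C(=O)[C@H]1C[C@@H]1C(=O)O` gives 13.5 nM in this assay.

Among these three numbers compound 2 stands second highest. Its nearest neighbour is compound 1: the step of a 1.3-fold higher number from compound 1 to compound 2 (0.11 log units; within the scatter) lies within the scatter, so the two compounds cannot be separated on the numbers shown. Its furthest neighbour is compound 3: the step of a 2.1-fold higher number from compound 2 to compound 3 (0.32 log units; beyond the scatter) lies beyond the scatter, though it is only modest.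

Compound 4 `COc1cc(N(CC2CC2)c2ccc(F)c(Cl)c2)cnc1C(=O)[C@H]1C[C@@H]1C(=O)O` differs from compound 2 in one place: 3-chloro-4-fluorophenyl in place of 3-(trifluoromethyl)phenyl on a nitrogen on an aromatic ring. Of the two measured steps, the one that bears on this change is a 1.3-fold higher number from compound 1 to compound 2 (0.11 log units; within the scatter), in which one aryl group on the same nitrogen was exchanged for another with a result within the scatter. The other step, a 2.1-fold higher number from compound 2 to compound 3 (0.32 log units; beyond the scatter), alters a different group on that nitrogen and says little here. On this basis no step beyond the scatter is expected in this assay from compound 2 to compound 4, in either direction. Compound 4 is therefore estimated at 5.5 nM, with a range from 2.5 nM to 12 nM. The expected step is a 1.2-fold lower number from compound 2 to compound 4 (0.07 log units; within the scatter).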

Compound 4, half-maximal inhibitory concentration: 5.26 nM
Beside the measured number, compound 4's estimate is 1.0-fold (0.02 log units) above it; low and high end bracket the measured number.
By their numbers in this assay, from the lowest: compounds 1, 4 and 2 (each within the scatter of the next); then compound 3.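

In this assay this place on the nitrogen now has a third aryl group, and the exchange of 3-(trifluoromethyl)phenyl for 3-chloro-4-fluorophenyl gives a 1.2-fold lower number from compound 2 to compound 4 (0.09 log units; within the scatter) and so cannot be told apart from no change. The earlier compounds shown here offered a single exchange of aryl groups here, whereas compounds 1, 2 and 4 now form a set of three with the same cyclopropyl-bearing chain on the nitrogen, and none of the steps printed among them lies beyond the scatter. The new pair also isolates one halogen on the ring, since fluoro in place of chloro on an aromatic carbon gives a 1.1-fold higher number from compound 1 to compound 4 (0.03 log units; within the scatter) and leaves the two compounds inseparable, though nothing shown here accounts for this flat result.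

From the compounds shown here alone, what remains open is whether an aryl group carrying a nitrile or an amine would stay as close to these three on the same nitrogen, or whether a step beyond the scatter would finally appear. The compounds shown also leave open whether the step seen with the 4-fluorophenyl group on the chain carries over to other aryl groups, and how a tetrazole in place of the carboxylic acid would read.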